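Replacing a cyclopropylamine with a methylpiperidine on the coumarin–pyrazoline amide

The compounds below may be only part of what the source reports. "The series", "measured", "known", "first", "only" and "open" are said of these compounds alone.

Compound 1 `CCNCC(=O)N1N=C(c2cc3ccccc3oc2=O)CC1c1ccccc1` and compound 2 `O=C(CNC1CC1)N1N=C(c2cc3ccccc3oc2=O)CC1c1ccccc1` share one core and differ only in the group on the amine nitrogen of the side chain. In a functional assay on PC-3 cells (Homo sapiens) for cytotoxicity, read by MTT assay, with a stated time of 48 h (a higher number here means a weaker inhibitor, a lower number a stronger inhibitor), compound 1 gives 5580 nM, and compound 2 gives 28500 nM. Within the data shown here, the step of a 5.1-fold higher number from compound 1 to compound 2 (0.71 log units; beyond the scatter) is the only comparison available, and it places compound 2 at the higher, weaker end of the two numbers measured so far.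

Compound 3 `CC1CCCN(CC(=O)N2N=C(c3cc4ccccc4oc3=O)CC2c2ccccc2)C1` is not yet measured. It differs from compound 2 by 3-methylpiperidin-1-yl in place of cyclopropylamino on a saturated chain carbon bound to a carbonyl carbon; in other words the secondary amine bearing a small ring gives way to a larger ring that itself contains the nitrogen. Among the measured compounds shown here, the one measured step touched the same amine, where a change from ethyl to cyclopropyl moved the number by a 5.1-fold higher number from compound 1 to compound 2 (0.71 log units; beyond the scatter), a modest effect. That step does not cover a ring closed onto the nitrogen, so the direction for compound 3 is uncertain; a step of a 2.4-fold lower number from compound 2 to compound 3 (0.38 log units; beyond the scatter) is expected, which is little more than the scatter. On that basis compound 3 is estimated at 12000 nM, with a likely range from 3500 nM to 45000 nM.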

Compound 3, half-maximal inhibitory concentration: 28300 nM
For compound 3 the middle estimate is 2.4-fold (0.37 log units) below the measured one, and the stated range covers the measured number.
By their numbers in this assay, from the lowest: compound 1; then compounds 3 and 2 (each within the scatter of the next).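

In this assay, the change to 3-methylpiperidin-1-yl on a saturated chain carbon bound to a carbonyl carbon gives a 1.0-fold lower number from compound 2 to compound 3 (0.00 log units; within the scatter) and so does not separate the two compounds, even though a group with 7 heavy atoms and 0 hydrogen-bond donors replaces one with 4 heavy atoms and 1 hydrogen-bond donor. Among the compounds shown, the amine nitrogen can therefore go from carrying a cyclopropyl ring to sitting inside a six-membered ring with no measurable shift in this cell read-out. Ethylamino still stands apart from this ring-containing group, with a 5.1-fold higher number from compound 1 to compound 3 (0.71 log units; beyond the scatter) as the step, and the data offer no measured explanation for either the match or the gap.

The compounds shown cannot tell whether the methyl on the piperidine matters, since the same ring without it, or with the methyl at another ring carbon, would be needed to isolate its part. Also open, going by these compounds, is how this position would respond to a morpholine, which puts an oxygen in the ring, or to a longer chain between the amine nitrogen and the carbonyl.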